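The source may report more compounds than this note shows. Statements on the series, on what has been measured and on what is new or still open speak of the compounds shown alone.

Measured so far:
- Compound 1 `Cc1ccc(NC2=CC(=O)c3c(nc4n3[C@H]3OC[C@@H](O)[C@H]3OC4)C2=O)cc1C`: 4950 nM
- Compound 2 `O=C1C=C(Nc2ccccc2)C(=O)c2c1nc1n2[C@H]2OC[C@@H](O)[C@H]2OC1`: a limit, > 4000 nM
- Compound 3 `O=C1C=C(Nc2ccc(C(F)(F)F)cc2)C(=O)c2c1nc1n2[C@H]2OC[C@@H](O)[C@H]2OC1`: a limit, > 4000 nM

Within the data shown here, in a functional assay on MCF7 cells (Homo sapiens) for inhibition, read by sulforhodamine B assay (a lower number here means a stronger inhibitor, a higher number a weaker inhibitor), compound 1 gives 4950 nM, the only full number among the three. For compound 2 the assay reports only a limit, > 4000 nM. For compound 3 it also reports only a limit, > 4000 nM. Among the measured compounds shown here, the single comparable step, a step that the two limits leave unreadable from compound 2 to compound 3, therefore cannot be sized, because both results sit at the limit of > 4000 nM in this assay, at which 2 of the 3 values shown sit.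

Compound 4 `O=C1C(N2CCCC2)=CC(=O)c2c1nc1n2[C@H]2OC[C@@H](O)[C@H]2OC1` has not been measured. It differs from compound 1 by pyrrolidin-1-yl in place of (3,4-dimethylphenyl)amino on a double-bonded ring carbon. For the measured compounds named here, none of the measured steps bears on this change: the one step available is unreadable and alters a different group. Going by the values given here, with compound 1 already a weak inhibitor and no guidance from the others, the expectation is only that compound 4 lands in the same weak region, most likely somewhat weaker, with a real chance of another limit. The step of a 1.6-fold higher number from compound 1 to compound 4 (0.21 log units; within the scatter) is expected to be small relative to the scatter. Compound 4 is estimated at 8000 nM, within 3000 nM to 25000 nM.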

Compound 4, half-maximal inhibitory concentration: > 16000 nM
Compound 4: only a limit was reported (the forecaster's own chance of this, stated with the estimate: 55%); middle value at least 2.0-fold (0.30 log units) away from the limit.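

Replacing (3,4-dimethylphenyl)amino with pyrrolidin-1-yl on the double-bonded ring carbon gives an at least 3.2-fold higher number from compound 1 to compound 4 (0.50 log units; beyond the scatter) in this assay. This is the first readable change among the compounds shown, and it indicates that the group at this carbon affects the result, although compound 4 gives only a limit, > 16000 nM. The change removes the aromatic ring and the hydrogen-bond donor together, so the shift cannot be assigned to either one alone.

A cyclohexylamino group, which keeps the donor without the aromatic ring, and an N-methylanilino group, which keeps the aromatic ring without the donor, would help separate the two. Also open, as far as these compounds go, is whether the two methyl groups of compound 1 matter, since compound 2 and compound 3 give only limits and their comparisons cannot be read.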